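Solubility of a pyrazolopyrimidine amine series: a fluoropyridinylmethyl analogue

This account rests on a few compounds, and the source may have more. Where it says the series, first, only, none or still open, it means among the compounds named here.

Measured so far in a physicochemical assay for solubility, read by HPLC, using the shake flask method, measured as kinetic solubility, with a stated time of 2 h, at pH 7.4; on this read-out lower numbers stand for lower solubility and higher numbers for higher solubility:
compound 1 `Cc1ccc(-c2cnn3c(NCc4ccccn4)cc(C)nc23)cc1`, < 5000 nM
compound 2 `Cc1cc(NCc2cnccn2)n2nc(C)c(-c3ccccc3)c2n1`, 7100 nM
compound 3 `Cc1cc(NCc2ccccn2)n2ncc(C3=CCC(F)(F)CC3)c2n1`, 5000 nM

The value for compound 1 is a limit of this assay, (the limit of < 5000 nM in this assay, at which 1 of the 3 values shown sits), and not a number. Compound 2 has the highest of the two numbers shown, with compound 3 close by and within the scatter. Within the data shown here, the one step between measured compounds, a number no lower from compound 1 to compound 3 (the limit leaves the size open), concerns a different place and its size is not readable, so no measured step bears on the change now considered. Compound 4 `Cc1cc(NCc2ccc(F)cn2)n2nc(C)c(-c3ccccc3)c2n1` differs from compound 2 by 5-fluoropyridin-2-yl in place of pyrazin-2-yl on a saturated chain carbon bound to a nitrogen on an aromatic ring. Among the measured compounds shown here, with no comparable step available, compound 4 is expected to sit near compound 2, with a step of a 1.4-fold lower number from compound 2 to compound 4 (0.15 log units; within the scatter), and its solubility is estimated at 5000 nM, within 2000 nM to 11000 nM.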

Compound 4, solubility: < 5000 nM
Compound 4 gave a limit, no number; the forecaster's own chance of this, stated with the estimate: 45%; the middle value lies on the limit itself.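

In this assay, among these compounds, the change from (pyrazin-2-yl)methyl to (5-fluoropyridin-2-yl)methyl gives the first step that can be read at this place, an at least 1.4-fold lower number from compound 2 to compound 4 (0.15 log units; that floor lies within the scatter). On these data alone, the value of compound 4 is a limit of the assay and not a number, so only the floor of this step is known and its full size stays open. Compound 4 shares that limit with compound 1: the limit of < 5000 nM in this assay, at which 2 of the 4 values shown sit.

The compounds shown leave open how a plain pyridin-2-yl group would read on the core of compound 2. They also leave open how a group carrying an amine or a carboxylic acid would read at this place.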